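The compounds below may be only part of what the source reports. "The series", "measured", "known", "first", "only" and "open" are said of these compounds alone.

Of the compounds shown here, three of the shared core have been measured so far in a functional assay on CHO-K1 cells for antagonist activity at adenosine receptor A1 (Homo sapiens), read by a beta-galactosidase reporter and cAMP accumulation, with stated times of 15 min and 6 h; a lower number here means a stronger inhibitor, a higher number a weaker inhibitor. Compound 1 `Cc1ccc(-c2nc(N)c3cc(Cc4ccccc4)sc3n2)o1` gives 298 nM; compound 2 `Nc1nc(C2CCCO2)nc2sc(Cc3ccccc3)cc12` gives 2950 nM; compound 3 `Nc1nc(-c2cccc(F)c2)nc2sc(Cc3ccccc3)cc12` gives 123 nM. Compound 3 stands lowest of the three: the nearest is compound 1, with a 2.4-fold lower number from compound 1 to compound 3 (0.38 log units; beyond the scatter), and the furthest is compound 2, with a 24-fold lower number from compound 2 to compound 3 (1.38 log units; beyond the scatter). The remaining step, a 9.9-fold higher number from compound 1 to compound 2 (1.00 log units; beyond the scatter), shows the same ordering.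

Compound 4 `Nc1nc(-c2ccncc2)nc2sc(Cc3ccccc3)cc12` is not yet measured. It differs from compound 3 in one place: pyridin-4-yl in place of 3-fluorophenyl on an aromatic carbon.

For the measured compounds named here, no measured step exchanges one six-membered aromatic ring for another, so the size of this step can only be bracketed. The step from compound 2 to compound 3 shows that an aromatic ring at this carbon is preferred over a saturated one, and the step from compound 1 to compound 3 shows that a five-membered heteroaromatic ring gives a somewhat higher number than the fluorophenyl. Since pyridin-4-yl keeps a six-membered aromatic ring, a step of modest size is expected, most likely towards a higher number, a 2.4-fold higher number from compound 3 to compound 4 (0.39 log units; beyond the scatter). For compound 4 the estimate is 300 nM, within a range of 100 nM to 1000 nM.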

Compound 4, inhibition constant: 812 nM
For compound 4 the middle estimate is 2.7-fold (0.43 log units) below the measured one; measured number inside the range.
By their numbers in this assay, from the lowest: compound 3; then compound 1; then compound 4; then compound 2.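

In this assay, exchanging one six-membered aromatic ring for another at this carbon is not a neutral change: 3-fluorophenyl giving way to pyridin-4-yl produces a 6.6-fold higher number from compound 3 to compound 4 (0.82 log units; beyond the scatter) and shows that a six-membered aromatic ring alone does not fix the number. Ring size does not sort the aromatic groups either, since pyridin-4-yl still improves on the saturated oxolan-2-yl, with a 3.6-fold lower number from compound 2 to compound 4 (0.56 log units; beyond the scatter) on that exchange, but falls behind the five-membered 5-methylfuran-2-yl, with a 2.7-fold higher number from compound 1 to compound 4 (0.44 log units; beyond the scatter) on that one, so this five-membered ring now sits between two six-membered rings in the order. No measurement at hand accounts for the step from 3-fluorophenyl to pyridin-4-yl.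

The step combines the loss of a fluorine on the ring with the entry of a ring nitrogen, and the compounds shown cannot separate the two, a question that unsubstituted phenyl at this carbon would address. Going by these compounds, whether the location of the ring nitrogen matters also stays open, as pyridin-3-yl and pyridin-2-yl would be needed to compare with pyridin-4-yl.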